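Methyl removal on a fused bicyclic naphthyl series

The source may hold more compounds than are shown below. What is called first, only, known or untested is meant among the compounds shown, and "the series" means these compounds.

Measured in a functional assay on MDA-N cells (Homo sapiens) for antiproliferative activity; a higher number here means a weaker inhibitor of growth, a lower number a stronger inhibitor of growth:

compound 1 `Oc1cc(-c2ccc3ccccc3c2)nc2ncccc12`: 1660 nM
compound 2 `Cc1cc(C)c2c(O)cc(-c3cccc4ccccc34)nc2n1`: 234 nM
compound 3 `Cc1ccnc2nc(-c3ccc4ccccc4c3)cc(O)c12`: 204 nM

Compound 3 and compound 1 differ in one place, (hydrogen in place of methyl on an aromatic carbon). That change gives an 8.1-fold higher number from compound 3 to compound 1 (0.91 log units; beyond the scatter), so losing the methyl weakens growth inhibition by a modest amount in this pair. Compound 2 and compound 3 are two different cores; how they differ is not broken down here. Their values lie within the scatter of each other, so no order between them is claimed, while compound 1 stands well apart from both.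

Compound 4 `Cc1ccc2c(O)cc(-c3cccc4ccccc34)nc2n1` has not yet been measured. Relative to compound 2 it carries hydrogen in place of methyl on an aromatic carbon. The place is not identical to that in the pair compound 3 to compound 1: in compound 2 the carbon that loses its methyl is also meta to a methyl group, which is absent in the earlier pair, so this is the same kind of change rather than the same change.

Among the compounds with values here, the expectation for compound 4 rests on the single earlier example: the step is expected to be a 7.3-fold higher number from compound 2 to compound 4 (0.86 log units; beyond the scatter), of about the size seen as an 8.1-fold higher number from compound 3 to compound 1 (0.91 log units; beyond the scatter), with wider uncertainty because only one pair supports it. Compound 4 is therefore expected to give 1700 nM in this assay, with the range 600 nM to 4800 nM as the expected spread.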

Compound 4, concentration for 50% growth inhibition: < 10 nM
Compound 4: a limit, no number; the forecaster's own chance of this, stated with the estimate: 3%; at least 170-fold (2.23 log units) between middle value and limit.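

In this assay compound 4 gives < 10 nM, a limit of the assay and not a number, so the true size of its step stays unknown in one direction: the limit of < 10 nM in this assay, at which 1 of the 4 values shown sits.

On the core of compound 2, hydrogen in place of methyl on an aromatic carbon gives an at least 23-fold lower number from compound 2 to compound 4 (1.36 log units; beyond the scatter), so the change does not carry over between the two cores, and its direction reverses: the same change on two cores in this assay, an 8.1-fold higher number (0.91 log units; beyond the scatter) from compound 3 to compound 1 and an at least 23-fold lower number (1.36 log units; beyond the scatter) from compound 2 to compound 4, at least 190-fold (2.27 log units) apart, beyond the scatter of two such steps

Within the data shown here, with only two pairs, this does not show what sets the direction of the step, whether that is the difference between the cores or the different place of the change, since the carbon in compound 2 is meta to a methyl group and the carbon in compound 3 is not.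

The compounds shown leave open whether the reversal would appear on a third core, and whether the core of compound 4 would stay at the limit with its remaining methyl also replaced by hydrogen. They also leave open how a group other than methyl on that aromatic carbon, such as an ethyl group, a methoxy group or an amine, would compare with hydrogen on each core.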